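Swapping fluoro for hydroxy on a more substituted ring

The compounds below may be only part of what the source reports. "The series", "measured", "known", "first", "only" and "open" are said of these compounds alone.

Four close relatives of one shared core are compared here. Compound 1 `C=CC[C@H]1C[C@]2([C@@H](C)Cc3ccc(OC)c(F)c3)OCOC2=CC1=O` serves as the reference, and in a functional assay on M14 cells (Homo sapiens) for antiproliferative activity, with a stated time of 72 h (on this read-out higher numbers stand for weaker inhibition and lower numbers for stronger inhibition), compound 1 gives 8 nM. Compound 2 `C=CC[C@H]1C[C@]2([C@@H](C)Cc3ccc(OC)c(O)c3)OCOC2=CC1=O` differs from compound 1 in a single place: hydroxy in place of fluoro on an aromatic carbon. In this assay compound 2 gives 8 nM, so the step is no change at the digits printed from compound 1 to compound 2 (within the scatter).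

Compound 3 `C=CC[C@H]1C[C@]2([C@@H](C)Cc3cc(F)c(OC)cc3F)OCOC2=CC1=O` also differs from compound 1 in one place: fluoro in place of hydrogen on an aromatic carbon. In this assay compound 3 gives 30 nM, and the step is a 3.8-fold higher number from compound 1 to compound 3 (0.57 log units; beyond the scatter). Compound 3 thus has the highest number of the three measured compounds, with both of its steps to the others lying beyond the scatter.

Compound 4 `C=CC[C@H]1C[C@]2([C@@H](C)Cc3cc(O)c(OC)cc3F)OCOC2=CC1=O` has not yet been measured. It differs from compound 3 in one place: hydroxy in place of fluoro on an aromatic carbon. Among the compounds with values here, this is the same kind of change as the one from compound 1 to compound 2, but not the same, since the surroundings differ: in compound 4 the place is also para to a fluoro group (1 heavy atom), which is not the case for compound 2. Because the earlier step of no change at the digits printed from compound 1 to compound 2 (within the scatter) stayed within the scatter, compound 4 is expected to land close to compound 3, with an expected step of no change at the digits printed from compound 3 to compound 4 (within the scatter). Compound 4 is therefore estimated to give about 30 nM in this assay, expected to fall between 12 nM and 75 nM.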

Compound 4, half-maximal inhibitory concentration: 9 nM
Compound 4: the middle estimate sits 3.3-fold (0.52 log units) above what was measured, and the stated range ends above it.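

In this assay the swap of fluoro for hydroxy gives a 3.3-fold lower number from compound 3 to compound 4 (0.52 log units; beyond the scatter), so a step read on the core of compound 1 does not carry over unchanged to the core of compound 3: the same change on two cores in this assay, no change at the digits printed (within the scatter) from compound 1 to compound 2 and a 3.3-fold lower number (0.52 log units; beyond the scatter) from compound 3 to compound 4, 3.3-fold (0.52 log units) apart, beyond the scatter of two such steps

Read the other way round, adding the aromatic fluoro to the hydroxy compound gives a 1.1-fold higher number from compound 2 to compound 4 (0.05 log units; within the scatter), and this step too differs from the one seen with the same addition to compound 1: the same change on two cores in this assay, a 3.8-fold higher number (0.57 log units; beyond the scatter) from compound 1 to compound 3 and a 1.1-fold higher number (0.05 log units; within the scatter) from compound 2 to compound 4, 3.3-fold (0.52 log units) apart, beyond the scatter of two such steps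

These two pairs show that, in this small set, the size of a step depends on what else the ring carries, but they do not show why, and they give no rule for how either change would behave on any further core.

The compounds shown leave open how an amine or a chloro group on the same aromatic carbon would read in this assay, and whether it would follow the hydroxy or the fluoro compounds. On these data alone, it also remains open whether the difference between the two steps would reappear with another group in place of the methoxy group, since every compound here carries that methoxy group.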